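The compounds below may be only part of what the source reports. "The series", "measured", "known", "first", "only" and "open" are said of these compounds alone.

Three related amides have been tested in a functional assay on QGY cells (Homo sapiens) for cytotoxicity, read by MTT assay, with a stated time of 48 h; a lower number here means a stronger inhibitor, a higher number a weaker inhibitor. Compound 1 `COc1cc([C@@H]2C[C@@]2(CO)C(=O)Nc2ccccc2)cc(OC)c1OC` gives 36700 nM, compound 2 `CCOC(=O)[C@]1(C(=O)Nc2ccccc2)C[C@@H]1c1cc(OC)c(OC)c(OC)c1` gives 38100 nM, and compound 3 `CCOC(=O)[C@@]1(C(=O)NCc2ccc(C)cc2)C[C@H]1c1cc(OC)c(OC)c(OC)c1` gives 26400 nM. Compound 3 stands level with the other two: its gap to each lies within the usual scatter of repeated measurements, so these numbers do not rank the three compounds.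

Compound 4 `CCOC(=O)[C@@]1(C(=O)Nc2ccccc2)C[C@H]1c1cc(OC)c(OC)c(OC)c1` has yet to be measured. Moving to it from compound 3 puts phenyl in place of 4-methylbenzyl on an amide-type nitrogen, which turns a (4-methylbenzyl)amino group into an anilino group: phenyl in place of 4-methylbenzyl on an amide-type nitrogen.

Among the measured compounds shown here, no two measured compounds differ in just one place, so this change has no direct precedent and any forecast rests on indirect evidence. Compound 2 also carries phenyl on that nitrogen and gives 38100 nM, which lies within the scatter of compound 3 at 26400 nM. On that basis, no change beyond the scatter is expected in this assay. The estimated step of a 1.3-fold higher number from compound 3 to compound 4 (0.10 log units; within the scatter) is expected to be small. For compound 4 the expected value is 33000 nM, with an estimated range from 15000 nM to 70000 nM.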

Compound 4, half-maximal inhibitory concentration: 48700 nM
Beside the measured number, compound 4's estimate is 1.5-fold (0.17 log units) below it; measured number inside the range.
By their numbers in this assay, from the lowest: compounds 3, 1, 2 and 4 (each within the scatter of the next).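

In this assay, the exchange of 4-methylbenzyl for phenyl on the amide-type nitrogen can now be read directly (a 1.8-fold higher number from compound 3 to compound 4 (0.27 log units; within the scatter)), and it stays within the scatter, so with the rest of the molecule held fixed, this change does not separate the two compounds. The same holds on the saturated ring carbon, where ethoxycarbonyl takes the place of hydroxymethyl (a 1.3-fold higher number from compound 1 to compound 4 (0.12 log units; within the scatter)), so that position shows no measurable response to this exchange either. The mirror-image pair also stays within the scatter (a 1.3-fold higher number from compound 2 to compound 4 (0.11 log units; within the scatter)), which means this assay does not distinguish the two drawn configurations, and the comparison is a clean one: the fact that compounds 2 and 4 differ only in the configuration as drawn.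

Still open, from the compounds shown here alone, is whether any group on that nitrogen could move the number beyond the scatter, such as a longer chain like 2-phenylethyl or a basic amine like 2-(dimethylamino)ethyl. Going by these compounds, it is equally open whether a carboxylic acid on the saturated ring carbon would do so, and whether configuration would matter with 4-methylbenzyl on the nitrogen rather than phenyl.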